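Replacing isopropyl with phenoxymethyl on a carbonyl carbon

This account rests on a few compounds, and the source may have more. Where it says the series, first, only, none or still open, it means among the compounds named here.

In a toxicity assay on KB cells (Homo sapiens) for cytotoxicity, read by fluorescence, with a stated time of 3 days (on this read-out lower numbers stand for an effect already at smaller amounts and higher numbers for an effect only at larger amounts of compound), compound 1 `CCCCOC(=O)CNC(=O)[C@H](CSc1ccc([N+](=O)[O-])cc1[N+](=O)[O-])NC(=O)CC[C@H](NC(=O)CCC(C)C)C(=O)OCCCC` gives 84 uM and compound 2 `CCCCOC(=O)CNC(=O)[C@H](CSc1ccc([N+](=O)[O-])cc1[N+](=O)[O-])NC(=O)CC[C@H](NC(=O)OCc1ccccc1)C(=O)OCCCC` gives 95.2 uM. These two values lie within the scatter, with a 1.1-fold higher number from compound 1 to compound 2 (0.05 log units; within the scatter).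

Compound 3 `CCCCOC(=O)CNC(=O)[C@H](CSc1ccc([N+](=O)[O-])cc1[N+](=O)[O-])NC(=O)CC[C@H](NC(=O)C(C)C)C(=O)OCCCC` stands at > 300 uM in this assay, which is a limit of the assay and not a number.

Compound 4 `CCCCOC(=O)CNC(=O)[C@H](CSc1ccc([N+](=O)[O-])cc1[N+](=O)[O-])NC(=O)CC[C@H](NC(=O)COc1ccccc1)C(=O)OCCCC` carries phenoxymethyl in place of isopropyl on a carbonyl carbon.

Among the measured compounds shown here, two measured steps bear on this change: an at least 3.5-fold higher number from compound 1 to compound 3 (0.55 log units; beyond the scatter) and an at least 3.1-fold higher number from compound 2 to compound 3 (0.49 log units; beyond the scatter). From the compounds shown here alone, both are beyond the scatter, but both end at a limit, so their true sizes remain open. Compound 2, with benzyloxy on the same carbonyl carbon, is the nearest reference for the incoming group, at 95.2 uM.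

A move toward a lower number, similar in size to those two steps, is expected, and the estimated step is an at least 3.0-fold lower number from compound 3 to compound 4 (0.47 log units; beyond the scatter).

For compound 4 the estimated value is 100 uM, with an expected range of 40 uM to 280 uM.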

Compound 4, concentration for half-maximal effect: > 300 uM
Compound 4: no number, only a limit (the forecaster's own chance of this, stated with the estimate: 20%); middle value at least 3.0-fold (0.47 log units) from the limit.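

In this assay, moving from benzyloxy to phenoxymethyl on this carbonyl carbon gives an at least 3.1-fold higher number from compound 2 to compound 4 (0.49 log units; beyond the scatter), so a six-membered aromatic ring in the group does not by itself keep the read-out at a measurable number. The change from the isopentyl compound reads the same way, with an at least 3.5-fold higher number from compound 1 to compound 4 (0.55 log units; beyond the scatter). Compound 3 and compound 4 end at the same assay limit, so the step between them cannot be read: the limit of > 300 uM in this assay, at which 2 of the 4 values shown sit.

Of the four groups shown, only isopentyl and benzyloxy give numbers, and what separates them from isopropyl and phenoxymethyl remains open. From the compounds shown here alone, how an amine, a carboxylic acid or a chain longer than isopentyl would read at this place in this assay also remains open.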